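The source may report more compounds than this note shows. Statements on the series, on what has been measured and on what is new or still open speak of the compounds shown alone.

Measured so far in a functional assay on PC-3 cells (Homo sapiens) for antiproliferative activity, read by MTT assay; a lower number here means a stronger inhibitor, a higher number a weaker inhibitor:
compound 1, `CNC(=O)c1ccc(Oc2cccc(NC(=S)Nc3ccc(F)c(F)c3)c2)nc1`, gives 23100 nM
compound 2, `CNC(=O)c1ccc(Oc2cccc(NC(=S)Nc3ccc(F)c(Cl)c3)c2)nc1`, gives 18400 nM
compound 3, `CNC(=O)c1ccc(Oc2cccc(NC(=S)Nc3cccc(C(F)(F)F)c3)c2)nc1`, gives 15400 nM

Compound 3 sits at the low end of these three numbers in this assay, but the steps of a 1.5-fold lower number from compound 1 to compound 3 (0.18 log units; within the scatter) and a 1.2-fold lower number from compound 2 to compound 3 (0.08 log units; within the scatter) are both within the scatter, so compound 3 is not set apart from compound 1 or compound 2 by anything the measurements can resolve.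

Compound 4, `CNC(=O)c1ccc(Oc2cccc(NC(=S)Nc3ccc(Cl)cc3)c2)nc1`, is not yet measured. It differs from compound 3 in one place:
4-chlorophenyl in place of 3-(trifluoromethyl)phenyl on an amide-type nitrogen

Among the compounds with values here, the steps that bear on this change are those that also exchange the aryl group on the amide-type nitrogen: a 1.5-fold lower number from compound 1 to compound 3 (0.18 log units; within the scatter) and a 1.2-fold lower number from compound 2 to compound 3 (0.08 log units; within the scatter). A halogen exchange on that same aryl group, a 1.3-fold lower number from compound 1 to compound 2 (0.10 log units; within the scatter), was likewise within the scatter. Nothing among the three measured compounds shows that varying this aryl group moves the number beyond the scatter, so for compound 4 a step of about a 1.1-fold higher number from compound 3 to compound 4 (0.04 log units; within the scatter) is expected, with no direction that can be called beyond the scatter. Compound 4 is therefore estimated at 17000 nM, within a range from 8000 nM to 36000 nM.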

Compound 4, half-maximal inhibitory concentration: 28400 nM
Beside the measured number, compound 4's estimate is 1.7-fold (0.22 log units) below it; low and high end bracket the measured number.
By their numbers in this assay, from the lowest: compounds 3, 2, 1 and 4 (each within the scatter of the next).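

In this assay, the exchange of aryl groups on the amide-type nitrogen now includes 4-chlorophenyl, and all three new steps stay within the scatter: a 1.8-fold higher number from compound 3 to compound 4 (0.27 log units; within the scatter), a 1.5-fold higher number from compound 2 to compound 4 (0.19 log units; within the scatter) and a 1.2-fold higher number from compound 1 to compound 4 (0.09 log units; within the scatter). The flat picture therefore extends to an aryl group with chlorine as its only halogen, and the four aryl groups at this position are not separated by these measurements. No independent data on these compounds are available to explain this result.

As far as these compounds go, it remains open whether a phenyl ring bearing an amine or a carboxylic acid would give a step beyond the scatter at this position. The same question stands for a longer alkyl chain in place of the aryl ring on that nitrogen.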